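The source may report more compounds than this note shows. Statements on the series, on what has been measured and on what is new or still open speak of the compounds shown alone.

Compound 1 `COc1cc(C)cc(-c2c(-c3ccnc(-c4ccc(C(C)=O)cc4)c3)cnn2CC#N)c1` carries an acetyl group on the outer phenyl ring. Within the data shown here, in a functional assay on Malme-3M cells (Homo sapiens) for cytotoxicity, read by sulforhodamine B assay, with a stated time of 48 h, tested at 1 uM (on this read-out higher numbers stand for a weaker effect at the one concentration tested and lower numbers for a stronger effect), compound 1 gives 36%, the highest of the three numbers measured so far. Compound 2 `Cc1cc(O)cc(-c2nn(CC#N)cc2-c2ccnc(-c3ccc(Oc4ccccc4)cc3)c2)c1`, with a phenoxy group in that position and a hydroxy rather than a methoxy group on the other side of the shared core, gives -75% in this assay. Compound 3 `Cc1cc(O)cc(-c2nn(CC#N)cc2-c2ccnc(-c3ccc(N(C)C)cc3)c2)c1`, which carries a dimethylamino group there, gives 27%, a number that sits within the scatter of compound 1.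

Among the measured compounds shown here, the only measured step bearing on the dimethylamino group is a number 102 percentage points higher from compound 2 to compound 3 (beyond the scatter). Compound 4 `COc1cc(C)cc(-c2c(-c3ccnc(-c4ccc(N(C)C)cc4)c3)cnn2CC#N)c1` differs from compound 1 in one place: dimethylamino in place of acetyl on an aromatic carbon. For the measured compounds named here, no measured pair shows an acetyl group exchanged for a dimethylamino group, but compound 3, which already holds the dimethylamino group, gives a number close to compound 1. The step is therefore expected to stay within the scatter, a number 6 percentage points lower from compound 1 to compound 4 (within the scatter). Compound 4 is estimated at 30%, with a range from 0% to 60%.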

Compound 4, a percentage reported as activity, at one concentration (the size of the read-out at that concentration, not a potency): 40%
Compound 4: the middle estimate sits 10 percentage points below what was measured; the measured number falls inside the stated range.
By their numbers in this assay, from the lowest: compound 2; then compounds 3, 1 and 4 (each within the scatter of the next, the first and the last beyond it).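

In this assay the exchange of 4-acetylphenyl for 4-(dimethylamino)phenyl gives a number 4 percentage points higher from compound 1 to compound 4 (within the scatter) and so, on the core of compound 1, these two groups with the same number of heavy atoms cannot be told apart. The earlier step of a number 102 percentage points higher from compound 2 to compound 3 (beyond the scatter) showed that the read-out can move strongly with a change at this place, while this result shows that not every change there moves it. No measurement at hand explains why the two groups read alike.

Among these compounds, it remains open whether phenoxy would also give a strongly lower number on the methoxy-bearing core of compound 1, since its only value comes from the hydroxy-bearing core. On these data alone, how a carboxylic acid or a primary amine would read at this same place also stays open.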